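The source may report more compounds than this note shows. Statements on the series, on what has been measured and on what is new or still open speak of the compounds shown alone.

Measured so far in a functional assay on cells (Erythrocyte, Rattus norvegicus) for inhibition, read by hemolysis, with a stated time of 1 h; on this read-out higher numbers stand for weaker inhibition and lower numbers for stronger inhibition:
compound 1, `COc1cc(OC)c(OC)cc1/C=C/C(=O)c1ccc(O)cc1`: 2.29 ug/mL
compound 2, `COc1cc(OC)c(OC)cc1/C=C/C(=O)c1ccc(-c2c[nH]cn2)cc1`: 2.48 ug/mL

Compound 2 carries the highest of the two numbers recorded, but its nearest neighbour, compound 1, sits a step away that is within the scatter a 1.1-fold higher number from compound 1 to compound 2 (0.03 log units; within the scatter), so the two compounds cannot be told apart on this read-out. Compound 3, `COc1cc(OC)c(OC)cc1/C=C/C(=O)c1ccc(F)cc1`, has not yet been measured. It differs from compound 2 in one place: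

fluoro in place of 1H-imidazol-4-yl on an aromatic carbon

Going by the values given here, no measured pair shows fluoro replacing 1H-imidazol-4-yl directly. Among the compounds with values here, the only step available, from hydroxy to 1H-imidazol-4-yl on the same aromatic carbon, gave a 1.1-fold higher number from compound 1 to compound 2 (0.03 log units; within the scatter), which means that exchanging the group at this position left the number essentially unchanged. On that evidence, compound 3 is expected to give a number close to that of compound 2, with a step of about a 1.0-fold higher number from compound 2 to compound 3 (0.00 log units; within the scatter) and no clear direction. The estimate for compound 3 in this assay is 2.5 ug/mL, with a range from 1.2 ug/mL to 5.5 ug/mL.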

Compound 3, half-maximal inhibitory concentration: 2.22 ug/mL
Estimate against measurement, compound 3: 1.1-fold (0.05 log units) above; measured number inside the range.
By their numbers in this assay, from the lowest: compounds 3, 1 and 2 (each within the scatter of the next).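

In this assay, fluoro in place of 1H-imidazol-4-yl gave a 1.1-fold lower number from compound 2 to compound 3 (0.05 log units; within the scatter) and fluoro in place of hydroxy gave a 1.0-fold lower number from compound 1 to compound 3 (0.01 log units; within the scatter) on the same aromatic carbon. The position para to a large group therefore gives numbers that cannot be told apart even when a five-membered aromatic ring of 5 heavy atoms, with 1 hydrogen-bond donor and 1 hydrogen-bond acceptor, gives way to a single fluorine atom with neither. No measurement at hand accounts for this sameness.

The compounds shown leave open whether an amine, a carboxylic acid or a longer alkyl chain at this position would give a number beyond the scatter of these three. They also leave open whether any other part of the shared core governs the number in this read-out.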